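The compounds below may be only part of what the source reports. "The series", "measured", "known", "first", "only" and "open" are said of these compounds alone.

Four naphthoquinone-bearing amides were tested for cytotoxicity. Compound 1 `CC(C)(CNC(=O)c1ccccc1O)CC1=C(O)C(=O)c2ccccc2C1=O` gives 28100 nM in a functional assay on MCF7 cells (Homo sapiens) for cytotoxicity, read by resazurin assay, with a stated time of 3 days; a higher number here means a weaker inhibitor, a lower number a stronger inhibitor. Compound 2 `CC(C)(CNC(=O)c1ccc2ccccc2c1O)CC1=C(O)C(=O)c2ccccc2C1=O` gives 79500 nM in this assay; the difference between the core of compound 2 and the core of compound 1 is not broken down here. Compound 3 `COc1ccc(O)c(C(=O)NCC(C)(C)CC2=C(O)C(=O)c3ccccc3C2=O)c1` gives 39600 nM. From compound 1 to compound 3 the change is methoxy in place of hydrogen on an aromatic carbon, and it made a 1.4-fold higher number from compound 1 to compound 3 (0.15 log units; within the scatter).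

Compound 4 `COc1cc(C(=O)NCC(C)(C)CC2=C(O)C(=O)c3ccccc3C2=O)c(O)c2ccccc12` is not yet measured. From compound 2 to compound 4 the change is methoxy in place of hydrogen on an aromatic carbon. This is the same kind of change as from compound 1 to compound 3, but here the aromatic carbon lies in a fused or bridged system of two rings, ortho to a fused ring and meta to a fused ring. Because the earlier step was a 1.4-fold higher number from compound 1 to compound 3 (0.15 log units; within the scatter), a step of a 1.3-fold higher number from compound 2 to compound 4 (0.10 log units; within the scatter) is expected in this assay. Compound 4 is therefore estimated at 100000 nM, with a range from 40000 nM to 250000 nM.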

Compound 4, half-maximal inhibitory concentration: 35600 nM
Compound 4: middle estimate off by 2.8-fold (0.45 log units), on the high side, and the stated range ends above it.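

Placed on the core of compound 2, methoxy in place of hydrogen on an aromatic carbon gave a 2.2-fold lower number from compound 2 to compound 4 (0.35 log units; beyond the scatter) in this assay. Within the data shown here, the change therefore did not carry over as one fixed step between these two cores: the same change on two cores in this assay, a 1.4-fold higher number (0.15 log units; within the scatter) from compound 1 to compound 3 and a 2.2-fold lower number (0.35 log units; beyond the scatter) from compound 2 to compound 4, 3.1-fold (0.50 log units) apart, beyond the scatter of two such steps This rests on only one pair of steps, and it does not show what in the two cores sets the steps apart or how the change would behave on any other core.

The compounds shown carry only methoxy or hydrogen at these aromatic carbons. As far as these compounds go, it remains open whether a longer ether such as ethoxy, or an amine, would follow the step seen on the core of compound 1 or the one seen on the core of compound 2.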